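The source may report more compounds than this note shows. Statements on the series, on what has been measured and on what is new or still open speak of the compounds shown alone.

The measured compounds:

Compound 1, `CN(C)c1ccc(/C=C/C=C/C(=O)c2ccccc2)cc1`, > 100000 nM
Compound 2, `CN(C)c1ccc(/C=C/C=C/C(=O)c2ccc(F)cc2)cc1`, > 100000 nM
Compound 3, `COc1cc(/C=C/C=C/C(=O)c2ccccc2)cc(OC)c1O`, 28700 nM

In an ADME assay on RAW264.7 cells (Mus musculus) for cytotoxicity, read by MTT assay (on this read-out lower numbers stand for stronger inhibition and higher numbers for weaker inhibition), compound 1 reaches only a limit of the assay, > 100000 nM. Compound 2 likewise stops at a limit, > 100000 nM. Compound 2 arises from compound 1 by fluoro in place of hydrogen on an aromatic carbon, and the step that the two limits leave unreadable from compound 1 to compound 2 cannot be read because of the limit of > 100000 nM in this assay, at which 2 of the 3 values shown sit. Going by the values given here, compound 3 is the one compound with a number in this assay, 28700 nM; how the core of compound 3 differs from the core of compound 1 is not broken down here.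

Compound 4, `COc1cc(/C=C/C=C/C(=O)c2ccc(F)cc2)cc(OC)c1O`, has not yet been measured. It arises from compound 3 by fluoro in place of hydrogen on an aromatic carbon, the same change that leads from compound 1 to compound 2. From the compounds shown here alone, the size of that change is unknown, since it has been measured only in the step from compound 1 to compound 2, whose size is not readable. The expectation for compound 4 therefore rests on compound 3 with its 28700 nM and assumes a step of a 1.0-fold higher number from compound 3 to compound 4 (0.02 log units; within the scatter). Compound 4 is therefore expected to give about 30000 nM, somewhere between 12000 nM and 80000 nM.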

Compound 4, half-maximal inhibitory concentration: 5000 nM
Compound 4: middle estimate off by 6.0-fold (0.78 log units), on the high side; the measured number lies below the stated range.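

On the core of compound 3, the change from phenyl to 4-fluorophenyl gives a 5.7-fold lower number from compound 3 to compound 4 (0.76 log units; beyond the scatter) in this assay. The same change on the core of compound 1 cannot be read, because compound 1 and compound 2 both stop at a limit of the assay rather than at a number: the limit of > 100000 nM in this assay, at which 2 of the 4 values shown sit. The size of this step is therefore known on one core only, so the pair of limits neither confirms nor contradicts that it carries from one core to another, and it does not show that the change has no effect on the core of compound 1.

The compounds shown leave open whether a chloro or a nitrile in place of the fluoro, on the same aromatic carbon, would give a step of similar size on the core of compound 3. They also leave open whether a step of this size would appear on a third core, one whose parent gives a number rather than a limit.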